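Chloro for fluoro on a second pyridinone-free core

The source may hold more compounds than are shown below. What is called first, only, known or untested is meant among the compounds shown, and "the series" means these compounds.

Of the compounds shown here, three have been measured in an ADME assay on L02 cells (Homo sapiens) for cytotoxicity, read by MTT assay, with a stated time of 24 h; on this read-out higher numbers stand for weaker inhibition and lower numbers for stronger inhibition. Compound 1 `COc1cc(/C=C2\CN(C)C/C(=C\c3ccc(F)cc3)C2=O)cc(OC)c1` gives 21900 nM. Compound 2 `COc1cc(/C=C2\CN(C)C/C(=C\c3ccc(Cl)cc3)C2=O)cc(OC)c1` gives 18900 nM. Compound 3 `CN1C/C(=C\c2ccc(F)cc2)C(=O)/C(=C/c2cccc([N+](=O)[O-])c2)C1` gives 17600 nM. Compound 2 arises from compound 1 by one change, (chloro in place of fluoro on an aromatic carbon), and the step is a 1.2-fold lower number from compound 1 to compound 2 (0.06 log units; within the scatter). The difference between the core of compound 1 and the core of compound 3 is not broken down here. Compound 4 `CN1C/C(=C\c2ccc(Cl)cc2)C(=O)/C(=C/c2cccc([N+](=O)[O-])c2)C1` arises from compound 3 by the same change, (chloro in place of fluoro on an aromatic carbon). The expected step is a 1.1-fold lower number from compound 3 to compound 4 (0.03 log units; within the scatter), because a 1.2-fold lower number from compound 1 to compound 2 (0.06 log units; within the scatter) stayed within the scatter. Compound 4 is therefore expected to give 16500 nM, with a range estimated from 8500 nM to 32000 nM.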

Compound 4, half-maximal inhibitory concentration: > 20000 nM
Compound 4: only a limit was reported; the forecaster's own chance of this, stated with the estimate: 5%; at least 1.2-fold (0.08 log units) between middle value and limit.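

In this assay compound 4 gives > 20000 nM, which is a limit of the assay and not a number. The step can therefore be read only as a floor, an at least 1.1-fold higher number from compound 3 to compound 4 (0.05 log units; that floor lies within the scatter), and setting it beside the earlier step gives no firm comparison: the same change on two cores in this assay, a 1.2-fold lower number (0.06 log units; within the scatter) from compound 1 to compound 2 and an at least 1.1-fold higher number (0.05 log units; that floor lies within the scatter) from compound 3 to compound 4; the limit leaves it open whether they differ The pair thus shows neither that chloro for fluoro carries from one core to the other nor that it fails to, and the limit gives no number for compound 4: the limit of > 20000 nM in this assay, at which 1 of the 4 values shown sits.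

The compounds shown leave open how a bromo group or an amine in place of the fluoro would read on either core. They also leave open how the change would read on a core other than these two.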